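Microsomal clearance notes: fluoro to 1,1-difluoroethyl

This account rests on a few compounds, and the source may have more. Where it says the series, first, only, none or still open, it means among the compounds named here.

Three compounds of this series have been run in an ADME assay on microsomes from liver (Mus musculus) for metabolic stability, read by LC-MS, using NADPH, with a stated time of 10 min, tested at 0.1 uM; on this read-out higher numbers stand for fast clearance and lower numbers for slow clearance. Compound 1 `O=C(NCCCCn1cccn1)c1cccc(C2SCC(=O)N2c2ccccn2)c1` gives 304 mL.min-1.g-1. Compound 2 `O=C(NCCCCc1ccccc1)c1cccc(C2SCC(=O)N2c2cccc(F)c2)c1` gives 2740 mL.min-1.g-1. Compound 3 `C#Cc1cc(C(=O)NCCCCc2ccccc2)cc(C2SCC(=O)N2c2ccccc2OC)c1` gives 2490 mL.min-1.g-1. Compound 2 thus stands at the upper end of the three numbers: the gap to compound 3 is within the usual scatter of repeated measurements, so the two cannot be ordered, whereas the gap to compound 1 lies well beyond the scatter, with compound 1 clearly the slower of the two. No pair of these compounds differs in a single place, so no step between measured compounds can be computed.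

Compound 4 `CC(F)(F)c1cccc(N2C(=O)CSC2c2cccc(C(=O)NCCCCc3ccccc3)c2)c1` has not yet been measured. It differs from compound 2 in one place: 1,1-difluoroethyl in place of fluoro on an aromatic carbon. The change sits on the same aromatic carbon, meta to a large group, as the fluoro of compound 2, and neither count of donors nor of acceptors moves.

For the measured compounds named here, nothing among the measured compounds isolates this exchange, so the step from compound 2 to compound 4 is expected to be no larger than the scatter, in either direction, giving a 1.1-fold higher number from compound 2 to compound 4 (0.02 log units; within the scatter) as the estimate. Compound 4 is therefore expected to come in near 2900 mL.min-1.g-1, with a range of 1300 mL.min-1.g-1 to 6000 mL.min-1.g-1 in this assay.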

Compound 4, intrinsic clearance in microsomes: 2010 mL.min-1.g-1
Beside the measured number, compound 4's estimate is 1.4-fold (0.16 log units) above it; the range from low to high includes it.
By their numbers in this assay, from the lowest: compound 1; then compounds 4, 3 and 2 (each within the scatter of the next).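

In this assay, for the compounds shown here, 1,1-difluoroethyl in place of fluoro on this aromatic carbon gives a 1.4-fold lower number from compound 2 to compound 4 (0.13 log units; within the scatter), the first reading of any change at this place. The position therefore takes an entering group of 4 heavy atoms in place of a leaving group of 1 heavy atom with no change in clearance that can be told apart from repeat measurement, and the same holds for the unchanged count of hydrogen-bond donors and acceptors across this pair. Neither group at this place can be ranked over the other on this read-out, and no measurement at hand explains the result.

On these data alone, whether an amine, a carboxylic acid or a hydroxyl on the same aromatic carbon would move the number beyond the scatter remains open. Also open, as far as these compounds go, is whether the exchange of fluoro for 1,1-difluoroethyl would read the same in another setting, such as on a compound carrying the other amide chain and the aromatic ring found in compound 1.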